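The compounds below may be only part of what the source reports. "The series", "measured", "known", "first", "only" and "open" are said of these compounds alone.

Compound 1 `C=CC1=C(C(=O)NCc2ccc(Cl)cc2)C(c2ccc(F)cc2)OC1`: 36900 nM
Compound 2 `C=CC1=C(C(=O)Nc2ccc(OCC)cc2)C(c2ccc(OC)cc2)OC1`: > 100000 nM

Both compounds were tested in a functional assay on QGY7701 cells (Homo sapiens) for cytotoxicity, read by MTT assay, with a stated time of 24 h; a higher number here means a weaker inhibitor, a lower number a stronger inhibitor. Compound 2 gives no number in this assay, only a limit, (the limit of > 100000 nM in this assay, at which 1 of the 2 values shown sits). Where compound 2 truly stands is therefore open: it could sit just past the limit or far beyond it.

Compound 3 `C=CC1=C(C(=O)NCc2ccc(Cl)cc2)C(c2ccc(OC)cc2)OC1` is not yet measured. It keeps the core and the 4-methoxyphenyl part of compound 2 but changes the amide: 4-chlorobenzyl in place of 4-ethoxyphenyl on an amide-type nitrogen. For the measured compounds named here, no measured pair differs in exactly this way, so the size of the step is uncertain. Compound 1 carries the same 4-chlorobenzyl on its amide-type nitrogen and gives 36900 nM in this assay, a number rather than a limit. On that basis compound 3 is expected to give a measurable number, and the step from compound 2 to compound 3 is estimated as an at least 2.5-fold lower number from compound 2 to compound 3 (0.39 log units; beyond the scatter). Compound 3 is estimated at 40000 nM, most likely between 12000 nM and 100000 nM.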

Compound 3, half-maximal inhibitory concentration: > 100000 nM
Compound 3: a limit, no number; the forecaster's own chance of this, stated with the estimate: 35%; middle value at least 2.5-fold (0.39 log units) from the limit.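

For the compounds shown here, with the 4-chlorobenzyl on the amide-type nitrogen held fixed, methoxy in place of fluoro on an aromatic carbon gives an at least 2.7-fold higher number from compound 1 to compound 3 (0.43 log units; beyond the scatter) in this assay, the first comparison here that isolates a change at this aromatic position. Compound 3 gives only a limit and not a number, so this step is a minimum, and the 4-chlorobenzyl group does not by itself yield a measurable value. The change of amide group from compound 2 to compound 3 cannot be read, as both compounds share the same limit: the limit of > 100000 nM in this assay, at which 2 of the 3 values shown sit.

Going by these compounds, how far compound 2 and compound 3 lie past that limit remains open. Also open, on these data alone, is whether an amine or a hydroxyl group on that aromatic carbon, with the 4-chlorobenzyl kept, would give a number.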